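A few compounds are considered here, and "the series" means these few. Any claim that something is new, unique, unknown or untested is made for them only; others in the source may bear on it.

Working notes on the series. Among the compounds with values here, compound 1, `NC1=NC2(CCOCC2)N(OCCCOc2cccc(Cl)c2)C(N)=N1`, is the one member with a number in hand: in a functional assay on MDA-MB-231 cells (Homo sapiens) for antiproliferative activity, read by MTT assay, with a stated time of 72 h (on this read-out higher numbers stand for weaker inhibition and lower numbers for stronger inhibition), compound 1 gives 1020 nM. Compound 2, `Cc1ccc(OCCCON2C(N)=NC(N)=NC23CCOCC3)cc1`, carries a 4-methylphenoxy group in place of the 3-chlorophenoxy group of compound 1, but in this assay compound 2 has "not determined" (no result reported), so compound 2 stands nowhere on the numbers shown and nothing can be said of how it compares with compound 1.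

Compound 3, `NC1=NC2(CCOCC2)N(OCCCOc2ccccc2Cl)C(N)=N1`, is the next point in the series. Its structure differs from that of compound 2 by 2-chlorophenyl in place of 4-methylphenyl on an oxygen on a saturated carbon. Within the data shown here, no step between two measured compounds is available for this change, so the size and direction of the shift in this assay from compound 2 to compound 3 cannot be read from the data; the only anchor is the chlorine-bearing analogue compound 1. Because compound 1 gives 1020 nM in this assay, compound 3 is expected to land near 1100 nM, with a plausible range of 400 nM to 3000 nM.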

Compound 3, half-maximal inhibitory concentration: 1430 nM
Beside the measured number, compound 3's estimate is 1.3-fold (0.11 log units) below it; measured number inside the range.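

In this assay, within the data shown here, the swap of 3-chlorophenyl for 2-chlorophenyl on an oxygen on a saturated carbon gives a 1.4-fold higher number from compound 1 to compound 3 (0.15 log units; within the scatter) and is the first step that can be read at this place. On this read-out the two chlorophenyl groups are not told apart, so the series now has two measured points at this place where compound 1 alone had offered one, and these two points agree within the usual scatter. No measurement bearing on this result is available, and no cause can be assigned to the step.

The step from compound 2 to compound 3 cannot be read, since compound 2 has no result, and 4-methylphenyl therefore remains unplaced against either chlorophenyl group. Still open, on these data alone, is whether another group at this place, such as 4-chlorophenyl, an aminophenyl or a carboxylic acid on the aromatic ring, or a longer chain leading to the oxygen, would move the number beyond the scatter.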